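A Chain Extension Tested for HeLa Cell Cytotoxicity

The source may hold more compounds than are shown below. What is called first, only, known or untested is meant among the compounds shown, and "the series" means these compounds.

Compound 1 `CCN1CCN(C(=S)SCC(O)Cn2c([N+](=O)[O-])cnc2C)CC1` and compound 2 `CCCCN1CCN(C(=S)SCC(O)Cn2c([N+](=O)[O-])cnc2C)CC1` share one core and differ only in the chain on the ring amine. In a toxicity assay on HeLa cells (Homo sapiens) for cytotoxicity, read by MTT assay, with a stated time of 24 h (a lower number here means a stronger inhibitor, a higher number a weaker inhibitor), compound 1 gives only a limit of the assay, > 5000000 nM. Compound 2 gives 1910000 nM in this assay. The change between them, (ethyl in place of hydrogen on a saturated chain carbon, two bonds along the chain from an amine nitrogen in a ring), produced a step of an at least 2.6-fold lower number from compound 1 to compound 2 (0.41 log units; beyond the scatter); since compound 1 sits at the limit of > 5000000 nM in this assay, at which 2 of the 3 values shown sit, only a lower bound of that step is known. Compound 3 `CCN1CCN(C(=S)SCC(O)Cn2cc([N+](=O)[O-])nc2C)CC1` has the same atoms as compound 1 joined differently; the difference between the two cores is not broken down here. In this assay compound 3 also gives only a limit, > 5000000 nM. Compound 4 `CCCCN1CCN(C(=S)SCC(O)Cn2cc([N+](=O)[O-])nc2C)CC1` stands to compound 3 as compound 2 stands to compound 1: the change is ethyl in place of hydrogen on a saturated chain carbon, two bonds along the chain from an amine nitrogen in a ring, the same change at the same place. The step from compound 3 to compound 4 is expected to be an at least 2.0-fold lower number from compound 3 to compound 4 (0.30 log units; that floor lies within the scatter), resting on the earlier step of an at least 2.6-fold lower number from compound 1 to compound 2 (0.41 log units; beyond the scatter) and on compound 3 starting at the limit. Compound 4 is therefore estimated at 2500000 nM in this assay, plausibly between 900000 nM and 6000000 nM.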

Compound 4, half-maximal inhibitory concentration: 4330000 nM
Compound 4: middle estimate off by 1.7-fold (0.24 log units), on the low side; the range from low to high includes it.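

On the core of compound 3, the change gives an at least 1.1-fold lower number from compound 3 to compound 4 (0.06 log units; that floor lies within the scatter) in this assay. This shows that a step of this change on one core does not fix its size on the other, but it also does not show that the two cores respond differently, and whether the steps match remains undecided: the same change on two cores in this assay, an at least 2.6-fold lower number (0.41 log units; beyond the scatter) from compound 1 to compound 2 and an at least 1.1-fold lower number (0.06 log units; that floor lies within the scatter) from compound 3 to compound 4; the limit leaves it open whether they differ Only lower bounds of the two steps can be read, and their true sizes stay unknown, since compound 1 and compound 3 each give only a limit of the assay: the limit of > 5000000 nM in this assay, at which 2 of the 4 values shown sit.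

The compounds shown leave open how large either step really is and whether the same change would read alike on a core other than these two. They also leave open how this assay would respond to a longer chain, such as hexyl, or to a benzyl group in the same place.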